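A few compounds are considered here, and "the series" means these few. Any claim that something is new, unique, unknown or untested is made for them only; others in the source may bear on it.

Measured compounds in a toxicity assay on L02 cells (Homo sapiens) for cytotoxicity, read by MTT assay, with a stated time of 72 h; a higher number here means a weaker inhibitor, a lower number a stronger inhibitor:

compound 1 `CC1(C)O[C@@H](CO)[C@H](Cn2cc(Cn3c4c(c5ccccc53)C(=O)c3c[n+]([O-])c5ccccc5c3C4=O)nn2)O1`: 500 nM
compound 2 `O=C1c2c[n+]([O-])c3ccccc3c2C(=O)c2c1c1ccccc1n2CCCCN1CCNCC1`: 1380 nM
compound 3 `CC1(C)OC[C@@H](Cn2cc(Cn3c4c(c5ccccc53)C(=O)c3c[n+]([O-])c5ccccc5c3C4=O)nn2)O1`: 2900 nM

All three share the same core. Among these three numbers compound 2 stands second highest: compound 3 lies above it by a gap beyond the scatter, and compound 1 lies below it by a gap that is also beyond the scatter, so compound 2 sits between the two.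

Compound 4 `O=C1c2c[n+]([O-])c3ccccc3c2C(=O)c2c1c1ccccc1n2CCN1CCCCC1` is not yet measured. It differs from compound 2 in one place: piperidin-1-yl in place of 2-(piperazin-1-yl)ethyl on a saturated chain carbon, two bonds along the chain from an aromatic nitrogen.

For the measured compounds named here, the only measured step, a 5.8-fold higher number from compound 1 to compound 3 (0.76 log units; beyond the scatter), concerns the dioxolane part of compound 1 and compound 3, which is far from the chain on the aromatic nitrogen of compound 2. Going by the values given here, no measured step therefore bears on the change from compound 2 to compound 4, and no direction can be read from the data. The expectation for compound 4 is a number close to that of compound 2, with a wide range, so that the estimated step of a 1.1-fold higher number from compound 2 to compound 4 (0.04 log units; within the scatter) may well stay within the scatter. For compound 4 in this assay the estimated value is 1500 nM, expected between 500 nM and 4500 nM.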

Compound 4, half-maximal inhibitory concentration: 1050 nM
Compound 4: middle estimate off by 1.4-fold (0.15 log units), on the high side, within the range that was stated.
By their numbers in this assay, from the lowest: compound 1; then compounds 4 and 2 (each within the scatter of the next); then compound 3.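

In this assay, replacing the 4-(piperazin-1-yl)butyl chain on the aromatic nitrogen with 2-(piperidin-1-yl)ethyl gives a 1.3-fold lower number from compound 2 to compound 4 (0.12 log units; within the scatter), so compound 2 and compound 4 cannot be told apart here. For the compounds shown here, this is the first view of this chain, and it shows that this particular change, which alters the chain length and the ring together, leaves the number within the scatter. Nothing available explains this result.

Going by these compounds alone, the single step cannot say whether chain length and ring would each have no effect alone, or whether two separate effects happen to cancel. A 4-(piperidin-1-yl)butyl or 2-(piperazin-1-yl)ethyl chain would separate the two changes, while a morpholin-4-yl ring on the same chain would test a different ring.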